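The source may hold more compounds than are shown below. What is called first, only, known or untested is meant among the compounds shown, and "the series" means these compounds.

Measured compounds:
Compound 1, `CC(C)OC(=O)OCOC(=O)C1=C(S[C@@H]2CN[C@H](C(=O)Nc3cccc(C(=O)O)c3)C2)[C@H](C)[C@@H]2[C@@H]([C@@H](C)O)C(=O)N12`, gives 62% in an ADME assay on a cell-free system (plasma, Homo sapiens) for metabolic stability, read by LC-MS, with a stated time of 60 min, at 37 degrees C, tested at 50 uM; on this read-out lower numbers stand for a less stable compound and higher numbers for a more stable compound.
Compound 2, `C[C@@H](O)[C@H]1C(=O)N2C(C(=O)OCOC(=O)OC3CCCCC3)=C(S[C@@H]3CN[C@H](C(=O)Nc4cccc(C(=O)O)c4)C3)[C@H](C)[C@H]12`, gives 46% in this assay.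
Compound 3, `COC(=O)OCOC(=O)C1=C(S[C@@H]2CN[C@H](C(=O)Nc3cccc(C(=O)O)c3)C2)[C@H](C)[C@@H]2[C@@H]([C@@H](C)O)C(=O)N12`, gives 33% in this assay.

Compound 3 stands lowest of the three numbers. Its nearest neighbour is compound 2, reached by a number 13 percentage points lower from compound 2 to compound 3 (beyond the scatter), and its furthest is compound 1, reached by a number 29 percentage points lower from compound 1 to compound 3 (beyond the scatter); both of these steps lie beyond the scatter, as does a number 16 percentage points lower from compound 1 to compound 2 (beyond the scatter).

Compound 4, `COC(=O)OCOC(=O)C1=C(S[C@@H]2CN[C@H](C(=O)Nc3cccc(C(=O)OCOC(=O)OC)c3)C2)[C@H](C)[C@@H]2[C@@H]([C@@H](C)O)C(=O)N12`, is not yet measured. It differs from compound 3 by ((methoxycarbonyl)oxy)methyl in place of hydrogen on an oxygen next to a carbonyl group. None of the three measured steps makes this kind of change: each of them exchanges one group for another on the oxygen next to the carbonyl group of the carbonate, whereas the step to compound 4 adds a group where a hydrogen stood, at a second place in the molecule. The measured steps therefore give no direct guide; they show only that this read-out responds to changes of this part of the structure by modest amounts. With that in mind, a step from compound 3 to compound 4 of a number 5 percentage points lower from compound 3 to compound 4 (within the scatter) is expected, with a wide range. Compound 4 is estimated at 28%, between 12% and 48%.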

Compound 4, percent of the compound remaining: 0%
Compound 4: middle estimate off by 28 percentage points, on the high side; the measured number lies below the stated range.
By their numbers in this assay, from the lowest: compound 4; then compound 3; then compound 2; then compound 1.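

Among compounds 1, 2 and 3, only the group on the oxygen of the carbonate changed, and the carboxy group stayed free throughout. Replacing its hydrogen with ((methoxycarbonyl)oxy)methyl, the change from carboxy to (((methoxycarbonyl)oxy)methoxy)carbonyl, gives a large step in this assay: a number 33 percentage points lower from compound 3 to compound 4 (beyond the scatter), so this second place in the molecule can also move the read-out, and the step is classed as large where those among the first three compounds were modest. Compound 4 gives 0%, the bottom of this read-out, which means the number cannot show how much sooner than the stated time the compound had gone, and no measurement at hand explains the loss.

The compounds shown do not tell whether the loss of compound 4 begins at the new group or at the carbonate it shares with compound 3. They also leave open how a simpler group at the carboxy place, such as a methyl ester or an amide, would behave, and whether the same change would give a similar result on the isopropyl carbonate of compound 1.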